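From 3,4-dichlorophenyl to 4-chlorophenyl

The compounds below may be only part of what the source reports. "The series", "measured", "known", "first", "only" and "open" are said of these compounds alone.

Measured in a functional assay on Molt4/C8 cells (Homo sapiens) for cytotoxicity; on this read-out higher numbers stand for weaker inhibition and lower numbers for stronger inhibition:
- compound 1 `O=C(/C=C/C(=O)N1C/C(=C\c2ccccc2)C(=O)/C(=C/c2ccccc2)C1)Nc1ccc(Cl)c(Cl)c1`: 1700 nM
- compound 2 `Cc1ccc(NC(=O)/C=C/C(=O)N2C/C(=C\c3ccc([N+](=O)[O-])cc3)C(=O)/C(=C/c3ccc([N+](=O)[O-])cc3)C2)cc1C`: 660 nM

Of these two compounds, compound 1 has the higher number, and compound 2 lies below it by more than the usual scatter. Compound 3 `O=C(/C=C/C(=O)N1C/C(=C\c2ccccc2)C(=O)/C(=C/c2ccccc2)C1)Nc1ccc(Cl)cc1` is still unmeasured. It departs from compound 1 by hydrogen in place of chloro on an aromatic carbon, with hydrogen in place of chloro on an aromatic carbon. Going by the values given here, no measured pair shows this change, so any expectation is tentative. In this assay, no step beyond the scatter is expected, and the estimate is a 1.1-fold lower number from compound 1 to compound 3 (0.03 log units; within the scatter). The estimated value for compound 3 is 1600 nM, within an expected range of 700 nM to 3800 nM.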

Compound 3, half-maximal inhibitory concentration: 1800 nM
Beside the measured number, compound 3's estimate is 1.1-fold (0.05 log units) below it, within the range that was stated.
By their numbers in this assay, from the lowest: compound 2; then compounds 1 and 3 (each within the scatter of the next).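

Taking away the chloro group ortho to the remaining chloro group gives a 1.1-fold higher number from compound 1 to compound 3 (0.02 log units; within the scatter) in this assay and so, for the first time, puts a size on this change: with the rest of compound 1 held fixed, 3,4-dichlorophenyl and 4-chlorophenyl cannot be told apart on this read-out. No measurement is available that could explain this result.

As far as these compounds go, whether this position accepts groups other than chloro and hydrogen remains open, for instance a methoxy group, an amine or a carboxylic acid. Also open, from the compounds shown here alone, is whether taking away the 4-chloro group instead would leave the read-out equally unmoved.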